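Sulfamoyl for acyl on the shared core: compound 4

This account rests on a few compounds, and the source may have more. Where it says the series, first, only, none or still open, it means among the compounds named here.

Measured in a functional assay (aorta) with Rattus norvegicus as the target; a lower number here means a stronger inhibitor, a higher number a weaker inhibitor:
compound 1 `CC1(C)Oc2ccc(C(=O)c3ccccc3)cc2[C@@H](/N=C(\NC#N)Nc2ccc(Cl)cc2)[C@@H]1O`: 7100 nM
compound 2 `CC(C)(C)C(=O)c1ccc2c(c1)[C@@H](/N=C(\NC#N)Nc1ccc(Cl)cc1)[C@H](O)C(C)(C)O2`: 5400 nM
compound 3 `CC1(C)Oc2ccc(S(=O)(=O)N3CCCC4CCCCC43)cc2[C@@H](/N=C(\NC#N)Nc2ccc(Cl)cc2)[C@@H]1O`: 8800 nM

Compound 2 gives the lowest of the three numbers, but the gaps to compound 1 and to compound 3 are both within the usual scatter, so the three compounds cannot be separated on these data.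

Compound 4 `CC(C)CN(CC(C)C)S(=O)(=O)c1ccc2c(c1)[C@@H](/N=C(\NC#N)Nc1ccc(Cl)cc1)[C@H](O)C(C)(C)O2` is not yet measured. It differs from compound 2 in one place: diisobutylsulfamoyl in place of (tert-butyl)carbonyl on an aromatic carbon.

For the measured compounds named here, one measured step bears on an exchange at this position: a 1.3-fold lower number from compound 1 to compound 2 (0.12 log units; within the scatter). That exchange left the number within the scatter. Compound 3 also carries a group joined through a sulfonyl rather than a carbonyl at this position and gives 8800 nM, which is within the scatter of compound 2. Going by the values given here, no measured pair shows a group at this position moving the number beyond the scatter, so for compound 4 no step beyond the scatter is expected in this assay, with any drift more likely toward the number of compound 3 than away from it.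

For compound 4 the expected value in this assay is 7000 nM, with a range of 3000 nM to 17000 nM. That expectation corresponds to a 1.3-fold higher number from compound 2 to compound 4 (0.11 log units; within the scatter).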

Compound 4, half-maximal inhibitory concentration: 9400 nM
Compound 4: the middle estimate sits 1.3-fold (0.13 log units) below what was measured; low and high end bracket the measured number.
By their numbers in this assay, from the lowest: compounds 2, 1, 3 and 4 (each within the scatter of the next).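

In this assay the exchange of (tert-butyl)carbonyl for diisobutylsulfamoyl on this aromatic carbon gives a 1.7-fold higher number from compound 2 to compound 4 (0.24 log units; within the scatter) and so stays inside the scatter, as does the exchange of benzoyl for the same group, with a 1.3-fold higher number from compound 1 to compound 4 (0.12 log units; within the scatter) on that step. On the sulfonyl sulfur, the open-chain group of compound 4 and the two-ring group of compound 3 also cannot be told apart, with a 1.1-fold higher number from compound 3 to compound 4 (0.03 log units; within the scatter) between them, so neither the acyl-to-sulfamoyl exchange nor the loss of the rings separates any of these compounds in this series. No measurement in hand accounts for this flat response at the position.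

All four groups shown here are neutral, and the compounds leave open whether any group at this position can move the number beyond the scatter, for example a carboxylic acid, a primary amine or a bare hydrogen. Also open, as far as these compounds go, is whether the same flat response would hold with a shorter chain on the sulfamoyl nitrogen, such as dimethylsulfamoyl, or with the 4-chlorophenyl group on the cyanoguanidine exchanged for another aryl group.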